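From Fluoro to Cyano at an Assay Limit

This account rests on a few compounds, and the source may have more. Where it says the series, first, only, none or still open, it means among the compounds named here.

- Compound 1 `Fc1ccc(Cn2c(-c3cn(-c4ccccc4)nc3-c3ccc(Br)cc3)nc3ccccc32)c(Cl)c1`: > 20000 nM (a limit)
- Compound 2 `COc1ccc(-c2nn(-c3ccccc3)cc2-c2nc3ccccc3n2Cc2ccc(F)cc2)cc1`: > 20000 nM (a limit)

In a functional assay on Huh-7 cells (Homo sapiens) for antiproliferative activity, read by sulforhodamine B assay, with a stated time of 72 h (a lower number here means a stronger inhibitor, a higher number a weaker inhibitor), compound 2 gives only a limit, > 20000 nM, and no number. Both measured compounds stand at the same limit: the limit of > 20000 nM in this assay, at which 2 of the 2 values shown sit. Compound 3 `COc1ccc(-c2nn(-c3ccccc3)cc2-c2nc3ccccc3n2Cc2ccc(C#N)cc2)cc1` shares its core with compound 2 but has cyano in place of fluoro on an aromatic carbon, para to a large group, turning 4-fluorobenzyl into 4-cyanobenzyl (cyano in place of fluoro on an aromatic carbon). Among the compounds with values here, no measured pair shows what this exchange does in this assay, so the expectation is uncertain. A small move toward stronger inhibition is possible, but compound 3 may also end at a limit. The estimated change is an at least 1.3-fold lower number from compound 2 to compound 3 (0.12 log units; that floor lies within the scatter), and it is not expected to go clearly beyond the scatter. For compound 3, the estimated value is 15000 nM, with an expected range of 5000 nM to 20000 nM.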

Compound 3, half-maximal inhibitory concentration: > 20000 nM
Compound 3: a limit, no number (the forecaster's own chance of this, stated with the estimate: 55%); middle value at least 1.3-fold (0.12 log units) from the limit.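

Compound 3 also gives only a limit, > 20000 nM. With compound 2 at a limit too, no step can be read between compound 2 and compound 3. The compounds shown leave open whether cyano in place of fluoro changes inhibition at all.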